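Shortening the Ether Side Chain on the Shared Core

The compounds below may be only part of what the source reports. "The series", "measured", "known", "first", "only" and "open" are said of these compounds alone.

Compound 3 `COCCOc1ccc2nccc(SC3(C(=O)O)CCC3)c2c1` gives 207 nM in an assay on HEK293 cells for inhibition of solute carrier family 22 member 12 (Homo sapiens), read by scintillation counting, with a stated time of 12 min (a higher number here means a weaker inhibitor, a lower number a stronger inhibitor), and so carries the lowest number among the values known here. Compound 2 `N#CCCc1ccc2nccc(SC3(C(=O)O)CCC3)c2c1` gives 2760 nM in this assay. Compound 1 `O=C(O)C1(Sc2ccnc3ccc(O)cc23)CCC1` reaches only the limit of this assay at > 10000 nM, which is a limit and not a number. The step of a 13-fold lower number from compound 2 to compound 3 (1.12 log units; beyond the scatter) was large, and the step of an at least 48-fold lower number from compound 1 to compound 3 (1.68 log units; beyond the scatter) was large as well. Compound 4 `COCc1ccc2nccc(SC3(C(=O)O)CCC3)c2c1` differs from compound 3 by methoxymethyl in place of 2-methoxyethoxy on an aromatic carbon. Both measured steps leading to compound 3 came with the 2-methoxyethoxy group, so trimming it to methoxymethyl in compound 4 is expected to raise the number by a modest amount. For compound 4 the estimated step is a 3.9-fold higher number from compound 3 to compound 4 (0.59 log units; beyond the scatter). Compound 4 is therefore expected to give about 800 nM, between 250 nM and 2500 nM.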

Compound 4, half-maximal inhibitory concentration: 198 nM
For compound 4 the middle estimate is 4.0-fold (0.61 log units) above the measured one; measured number outside the range, below it.
By their numbers in this assay, from the lowest: compounds 4 and 3 (each within the scatter of the next); then compound 2. At a limit, above all of these: compound 1.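

Swapping 2-methoxyethoxy for methoxymethyl on this aromatic carbon gives a 1.0-fold lower number from compound 3 to compound 4 (0.02 log units; within the scatter) in this assay, so an oxygen bound directly to the aromatic carbon is not needed to hold this level. Methoxy in place of cyanomethyl on the saturated chain carbon gives a 14-fold lower number from compound 2 to compound 4 (1.14 log units; beyond the scatter), which shows that the end of the side chain counts even when the carbon on the aromatic ring stays the same. Methoxymethyl in place of hydroxy gives an at least 50-fold lower number from compound 1 to compound 4 (1.70 log units; beyond the scatter), and the value of compound 1 is a limit, not a number: the limit of > 10000 nM in this assay, at which 1 of the 4 values shown sits.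

From the compounds shown here alone, whether an amine or a longer chain ending in methoxy would fit on this aromatic carbon stays open. So does the outcome for a plain methyl group, which has no oxygen.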